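The source may report more compounds than this note shows. Statements on the series, on what has been measured and on what is new or still open speak of the compounds shown alone.

Measured compounds:
compound 1, `COc1nc(C)c(Nc2nc(Cl)cn([C@H](COC(=O)Nc3ccccc3)C3CC3)c2=O)cc1C`, 1.5 nM
compound 2, `COc1ccc(NC(=O)OC[C@H](C2CC2)n2cc(Cl)nc(Nc3cc(C)c(OC)nc3C)c2=O)c(C)n1`, 9.2 nM

Both were run in an assay on frontal cortex for displacement of a labelled ligand from corticotropin-releasing factor receptor 1 (Rattus norvegicus), with a stated time of 2 h; on this read-out lower numbers stand for stronger inhibition and higher numbers for weaker inhibition. Within this pair compound 2 stands at the higher number; compound 1 sits at the lower one, and the step of a 6.1-fold higher number from compound 1 to compound 2 (0.79 log units; beyond the scatter) lies beyond the scatter, so the aryl group on the amide-type nitrogen matters for the read-out.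

Compound 3, `COc1nc(C)c(Nc2nc(Cl)cn([C@H](COc3cccnc3)C3CC3)c2=O)cc1C`, has not yet been measured in this assay. Relative to compound 2 the change is pyridin-3-yl in place of (6-methoxy-2-methylpyridin-3-yl)carbamoyl on an oxygen on a saturated carbon. For the measured compounds named here, the only measured step, from compound 1 to compound 2, touches the same end of the molecule but swaps one aryl group for another on the carbamate nitrogen, whereas here the whole carbamoyl unit leaves and a bare pyridin-3-yl enters on the oxygen. That step gives a sense of scale but not of direction. The expectation for compound 3 is therefore a step of a 1.5-fold lower number from compound 2 to compound 3 (0.19 log units; within the scatter), with the number in this assay estimated at 6 nM, in the range 1.5 nM to 25 nM.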

Compound 3, half-maximal inhibitory concentration: 6.7 nM
Compound 3: the middle estimate sits 1.1-fold (0.05 log units) below what was measured, within the range that was stated.
By their numbers in this assay, from the lowest: compound 1; then compounds 3 and 2 (each within the scatter of the next).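

In this assay the whole carbamoyl unit can leave the oxygen on a saturated carbon: with pyridin-3-yl in place of (6-methoxy-2-methylpyridin-3-yl)carbamoyl, the outcome is a 1.4-fold lower number from compound 2 to compound 3 (0.14 log units; within the scatter), so this assay does not tell these two groups apart. The same position does respond when phenylcarbamoyl is the group replaced, with a 4.5-fold higher number from compound 1 to compound 3 (0.65 log units; beyond the scatter), so the phenylcarbamoyl group of compound 1 remains ahead of pyridin-3-yl on that oxygen. No measurement at hand offers an explanation for either outcome.

Both steps change the linking carbamoyl unit and the aromatic ring at once, so the part played by each stays unresolved. A phenyl group directly on the oxygen, or a pyridin-3-yl carrying a methoxy group, would help separate them.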